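Methyl on the saturated ring of compound 2

This account rests on a few compounds, and the source may have more. Where it says the series, first, only, none or still open, it means among the compounds named here.

Among the compounds with values here, compound 2 `COc1cc2c(Oc3ccc(NC(=O)c4cc(-c5ccc(C)cc5)nc5ccc(F)cc45)cc3F)ccnc2cc1OCCCN1CCCCC1` gives the higher of the two numbers so far in a functional assay on MKN-45 cells (Homo sapiens) for cytotoxicity, read by MTT assay, with a stated time of 72 h; a lower number here means a stronger inhibitor, a higher number a weaker inhibitor: compound 2 gives 170 nM, whereas compound 1 `COc1cc2c(Oc3ccc(NC(=O)c4cc(-c5ccccc5)nc5ccc(F)cc45)cc3F)ccnc2cc1OCCCN1CCCCC1` gives 30 nM. Within the data shown here, the only measured step in the set is a 5.7-fold higher number from compound 1 to compound 2 (0.75 log units; beyond the scatter), a methyl in place of hydrogen on an aromatic carbon. Compound 3 `COc1cc2c(Oc3ccc(NC(=O)c4cc(-c5ccc(C)cc5)nc5ccc(F)cc45)cc3F)ccnc2cc1OCCCN1CCC(C)CC1` carries a different change, (methyl in place of hydrogen on a saturated ring carbon). Among the measured compounds shown here, the measured step concerns an aromatic carbon, not a saturated ring carbon of the six-membered non-aromatic ring with one nitrogen, so it bears on the present change only loosely, and no step at such a ring carbon has been measured. The expected step in this assay is therefore a 1.2-fold higher number from compound 2 to compound 3 (0.07 log units; within the scatter), within the usual scatter, with no clear direction. Compound 3 is expected to give 200 nM, with a range of 80 nM to 500 nM.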

Compound 3, half-maximal inhibitory concentration: 260 nM
Beside the measured number, compound 3's estimate is 1.3-fold (0.11 log units) below it, and the stated range covers the measured number.
By their numbers in this assay, from the lowest: compound 1; then compounds 2 and 3 (each within the scatter of the next).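

Within the data shown here, the piperidin-1-yl to 4-methylpiperidin-1-yl change gives the first measured step at a saturated ring carbon, three ring bonds from the ring nitrogen: in this assay it is a 1.5-fold higher number from compound 2 to compound 3 (0.18 log units; within the scatter). On the background of compound 2, this ring carbon therefore accepts a methyl with no step beyond the scatter, whereas methyl on the aromatic carbon gave a 5.7-fold higher number from compound 1 to compound 2 (0.75 log units; beyond the scatter). No measurement at hand accounts for either step.

On these data alone, it remains open whether the 4-methylpiperidin-1-yl change would read the same on the background of compound 1, without the aromatic methyl. As far as these compounds go, the effect of a hydroxyl, an amine or a carboxylic acid at this same ring carbon also remains open, as does that of a longer chain such as ethyl or propyl.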